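Swapping a Hydroxypyrrolidine for a Carboxy-Hydroxypropyl Amine

This account rests on a few compounds, and the source may have more. Where it says the series, first, only, none or still open, it means among the compounds named here.

Compound 3 `COc1ccc(/C=C\c2cc(OC)c(OC)c(OC)c2)cc1OCc1ccc(CN2CC[C@H](O)C2)cc1` is one of three close relatives sharing the same core, tested for toxicity toward normal colon cells in an ADME assay on NCM460 cells (Homo sapiens) for cytotoxicity, read by CCK-8 assay, with a stated time of 48 h; on this read-out lower numbers stand for stronger inhibition and higher numbers for weaker inhibition. In this assay compound 3 gives 51000 nM, and compound 2 `COc1ccc(/C=C\c2cc(OC)c(OC)c(OC)c2)cc1OCc1ccc(CN2CC[C@@H](O)C2)cc1` gives 53000 nM, a practically identical reading. These two differ only in configuration as drawn (the fact that compounds 2 and 3 differ only in the configuration as drawn), and the step of a 1.0-fold lower number from compound 2 to compound 3 (0.02 log units; within the scatter) lies within the scatter. Compound 1 `COc1ccc(/C=C\c2cc(OC)c(OC)c(OC)c2)cc1OCc1ccc(CN[C@H](C(=O)O)[C@H](C)O)cc1` carries a different group on the same chain carbon; in this assay compound 1 reaches only the limit, > 50000 nM (the limit of > 50000 nM in this assay, at which 1 of the 3 values shown sits). Because of that limit the step that the limit leaves unreadable from compound 1 to compound 3 cannot be read in size. Compound 4 `COc1ccc(/C=C\c2cc(OC)c(OC)c(OC)c2)cc1OCc1ccc(CN[C@H](C(=O)O)[C@@H](C)O)cc1` differs from compound 3 by (1-carboxy-2-hydroxypropyl)amino in place of 3-hydroxypyrrolidin-1-yl on a saturated chain carbon bound to an aromatic carbon. Among the compounds with values here, since the only measured compound bearing this entering group, compound 1, gave just a limit > 50000 nM, compound 4 is expected to stay weak as well, with a step of about a 1.1-fold higher number from compound 3 to compound 4 (0.03 log units; within the scatter) expected. The estimate for compound 4 is 55000 nM, within a range from 35000 nM to 120000 nM, and the assay may well return only a limit again.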

Compound 4, half-maximal inhibitory concentration: > 50000 nM
Compound 4 ended at the assay's limit; the forecaster's own chance of this, stated with the estimate: 70%; the middle value does not contradict the limit.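

Compound 4 reads only as a limit, so its steps from compound 1, compound 2 and compound 3 cannot be read in size. On these data alone, whether the configuration at that chain carbon separates compound 1 from compound 4 in this assay stays open, as does how either compares with compound 2 or compound 3.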